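Working notes: 2,4-dimethoxyphenyl for 2-fluorophenyl in a pyridinyl-ether series

The source may hold more compounds than are shown below. What is called first, only, known or untested is meant among the compounds shown, and "the series" means these compounds.

Measured so far:
- Compound 2 `COc1cc(Nc2cc(Nc3ccc(Oc4ccncc4-c4cccnc4)c(F)c3)ncn2)cc(OC)c1` in a functional assay on MDA-MB-231 cells (Homo sapiens) for cytotoxicity, read by MTT assay, with a stated time of 72 h (a higher number here means a weaker inhibitor, a lower number a stronger inhibitor), gives 4240 nM.
- Compound 3 `Cn1c(=O)c(C(=O)Nc2ccc(Oc3ccncc3-c3cccnc3)c(F)c2)nn(-c2ccccc2F)c1=O` in this assay gives 6760 nM.
- Compound 1 `Fc1cc(Nc2cc(Nc3ccc(Cl)cc3)ncn2)ccc1Oc1ccncc1-c1cccnc1` in this assay is recorded as "not determined" (no result reported).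

Among the compounds with values here, only two numbers exist in this assay. Compound 3 and compound 2 sit within the scatter of each other, so on the numbers shown neither stands apart from the other; compound 1 adds nothing here. Within the data shown here, no step between measured compounds that differ in one place is available, so there is no measured guide for the change considered next.

Compound 4 `COc1ccc(-n2nc(C(=O)Nc3ccc(Oc4ccncc4-c4cccnc4)c(F)c3)c(=O)n(C)c2=O)c(OC)c1` differs from compound 3 in one place: 2,4-dimethoxyphenyl in place of 2-fluorophenyl on an aromatic nitrogen. The 2,4-dimethoxyphenyl takes the position of the 2-fluorophenyl on an aromatic nitrogen of the six-membered aromatic ring with 3 nitrogen, next to the ring nitrogen, with the rest of compound 3 unchanged.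

Among the measured compounds shown here, with no measured step on this side of the molecule, no shift beyond the scatter is expected; the step from compound 3 to compound 4 in this assay is estimated as a 1.1-fold lower number from compound 3 to compound 4 (0.05 log units; within the scatter). Compound 4 is therefore expected to give about 6000 nM in this assay, with a range from 2500 nM to 15000 nM.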

Compound 4, half-maximal inhibitory concentration: 3270 nM
Compound 4: the middle estimate sits 1.8-fold (0.26 log units) above what was measured; the range from low to high includes it.
By their numbers in this assay, from the lowest: compounds 4, 2 and 3 (each within the scatter of the next, the first and the last beyond it).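

In this assay, within the data shown here, 2,4-dimethoxyphenyl in place of 2-fluorophenyl on an aromatic nitrogen gives a 2.1-fold lower number from compound 3 to compound 4 (0.32 log units; beyond the scatter), the first measured step and the first measured sign that a change at this position can move the number beyond the usual scatter, though only modestly. The entering group is the larger of the two, with 10 heavy atoms against 7 and 2 hydrogen-bond acceptors against 0, and the number in this assay does not rise with it, so this position accepts the 2,4-dimethoxyphenyl without a loss of cytotoxic effect on these cells. Nothing available bears on what lies behind this step.

Among these compounds, the single step changes both the fluorine and the two methoxy groups at once, so it remains open whether a plain phenyl or a phenyl with a single methoxy group would give the same shift. As far as these compounds go, it also remains open whether the position accepts groups of another kind, such as a morpholine, a carboxylic acid or a longer alkyl chain, and whether the step holds in any setting beyond these cells.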